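Chloro in place of methyl: from compound 3 to compound 4

A few compounds are considered here, and "the series" means these few. Any claim that something is new, unique, unknown or untested is made for them only; others in the source may bear on it.

Measured so far in a functional assay on DU-145 cells (Homo sapiens) for inhibition, read by CCK-8 assay, with a stated time of 72 h (on this read-out higher numbers stand for weaker inhibition and lower numbers for stronger inhibition), for this series:
- compound 1 `O=C(/C=C/c1cccnc1)NCCCc1ccc(S(=O)(=O)Nc2ccccc2)cc1` gives > 10000 nM as a limit of the assay
- compound 2 `O=C(/C=C/c1cccnc1)NCCCCCCCc1cccc(S(=O)(=O)Nc2ccccc2)c1` gives 429 nM as a number
- compound 3 `Cc1ccc(NS(=O)(=O)c2cccc(CCCCCCNC(=O)/C=C/c3cccnc3)c2)cc1` gives 34.4 nM as a number

Compound 3 holds the lowest number among the values shown, and the gap to compound 2 lies beyond the usual scatter. The result for compound 1 is only a limit.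

Compound 4 `O=C(/C=C/c1cccnc1)NCCCCCCc1cccc(S(=O)(=O)Nc2ccc(Cl)cc2)c1` departs from compound 3 in one place (chloro in place of methyl on an aromatic carbon), with chloro in place of methyl on an aromatic carbon, para to a large group. Among the measured compounds shown here, no measured pair isolates a change at this position, so the expectation rests on compound 3 at 34.4 nM as the only close anchor. In this assay no step beyond the scatter is expected, and neither direction is favoured. The estimated change (a 1.2-fold higher number from compound 3 to compound 4 (0.07 log units; within the scatter)) is therefore small. Compound 4 is estimated at 40 nM in this read-out, with an expected range of 12 nM to 130 nM for repeat measurements.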

Compound 4, half-maximal inhibitory concentration: 84.4 nM
Compound 4: the middle estimate sits 2.1-fold (0.32 log units) below what was measured, within the range that was stated.
By their numbers in this assay, from the lowest: compound 3; then compound 4; then compound 2. At a limit, above all of these: compound 1.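

Among the compounds shown here, exchanging 4-methylphenyl for 4-chlorophenyl in this assay gives a 2.5-fold higher number from compound 3 to compound 4 (0.39 log units; beyond the scatter) and is the first measured step that isolates this position. The position, para to a large group, therefore responds to a single-atom exchange, and compound 4 still gives 84.4 nM as a number rather than a limit. Nothing measured here accounts for the size or direction of this step.

As far as these compounds go, whether the step is particular to chloro remains open, since a methoxy, trifluoromethyl or fluoro group at the same position would show whether the methyl result in compound 3 stands apart. From the compounds shown here alone, it is also open whether the same exchange of methyl for chloro gives a similar step on a longer chain or with the sulfamoyl group placed elsewhere on the ring.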